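The compounds below may be only part of what the source reports. "The series", "measured", "known", "first", "only" and "open" are said of these compounds alone.

Measured compounds:
- compound 1, `Nc1ccc(-c2nc3cc(F)ccc3s2)cc1`: 11500 nM
- compound 2, `Cc1cc(-c2nc3ccc(F)cc3s2)ccc1N`: see below
- compound 3, `Cc1cc(-c2nc3c(F)cccc3s2)ccc1N`: no result reported

In a functional assay on cells (Cancer cell lines, Homo sapiens) for inhibition (a higher number here means a weaker inhibitor of growth, a lower number a stronger inhibitor of growth), compound 1 gives 11500 nM. For compound 2 this assay reports only a limit, < 10 nM, which is the limit of < 10 nM in this assay, at which 1 of the 3 values shown sits. Compound 3 carries the same aminomethylphenyl part as compound 2 but with fluoro moved to another carbon of the fused ring; for compound 3 this assay gives no result reported, so it stands outside the comparison of values. The step from compound 3 to compound 4, `Cc1cc(-c2nc3ccccc3s2)ccc1N`, is hydrogen in place of fluoro on an aromatic carbon, (hydrogen in place of fluoro on an aromatic carbon). Going by the values given here, no measured step shows what this change does, and the two values at hand differ in more than one place, so no direct calibration is available. The expectation is that removing fluoro shifts this assay only modestly, likely within or just beyond the scatter, with compound 4 resembling compound 2 more than compound 1. Compound 4 is estimated at 30 nM, between 5 nM and 300 nM.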

Compound 4, concentration for 50% growth inhibition: < 10 nM
Compound 4: only a limit was reported; the forecaster's own chance of this, stated with the estimate: 25%; middle value at least 3.0-fold (0.47 log units) away from the limit.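

No new step can be read between compound 2 and compound 4, as each carries only a limit in this assay: the limit of < 10 nM in this assay, at which 2 of the 4 values shown sit.

The compounds shown leave open whether hydrogen in place of fluoro on an aromatic carbon shifts growth inhibition at all.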